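Bromo substitution and half-life across two cores

This account rests on a few compounds, and the source may have more. Where it says the series, first, only, none or still open, it means among the compounds named here.

Measured so far in an ADME assay on microsomes from liver (Homo sapiens) for metabolic stability; on this read-out lower numbers stand for a shorter-lived compound and higher numbers for a longer-lived compound:
Compound 1 `CCCNC(=O)C1CCN(C(=O)c2cc3scnc3n2Cc2ccc(OC)cc2)CC1` gives 0.462 h.
Compound 2 `CCCNC(=O)C1CCN(C(=O)c2cccn2Cc2ccc(OC)cc2)CC1` gives 0.112 h.
Compound 3 `CCCNC(=O)C1CCN(C(=O)c2cc3sc(Br)nc3n2Cc2ccc(OC)cc2)CC1` gives 0.0498 h.

Compound 3 differs from compound 1 by bromo in place of hydrogen on an aromatic carbon, and the step is a 9.3-fold lower number from compound 1 to compound 3 (0.97 log units; beyond the scatter). Compound 2 carries a different core; the difference between the two cores is not broken down here. Compound 2 stands between the other two, with a shorter half-life than compound 1 and a longer one than compound 3, both gaps beyond the scatter.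

Compound 4 `CCCNC(=O)C1CCN(C(=O)c2ccc(Br)n2Cc2ccc(OC)cc2)CC1` is not yet measured. It differs from compound 2 by bromo in place of hydrogen on an aromatic carbon. This is the same kind of change as that from compound 1 to compound 3, but the place is not identical: in compound 3 the bromo sits on a ring with 1 nitrogen and 1 sulfur, part of a fused or bridged system of two rings, next to the ring sulfur, whereas in compound 4 it sits on a five-membered ring with 1 nitrogen, next to the ring atom that bears a 4-methoxybenzyl group.

In this assay compound 4 is expected to show a shorter half-life than compound 2, a step of about a 5.6-fold lower number from compound 2 to compound 4 (0.75 log units; beyond the scatter), because compound 1 to compound 3 gave a 9.3-fold lower number from compound 1 to compound 3 (0.97 log units; beyond the scatter); the different surroundings leave the size uncertain. Compound 4 is therefore estimated at 0.02 h, between 0.008 h and 0.06 h.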

Compound 4, half-life: 0.122 h
The estimate for compound 4 lay 6.1-fold (0.79 log units) below the measured number; the measured number lies above the stated range.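

In this assay the new step is a 1.1-fold higher number from compound 2 to compound 4 (0.04 log units; within the scatter) and lies within the scatter, so on this core the two compounds cannot be told apart on half-life. Bromo in place of hydrogen on an aromatic carbon therefore does not carry a single step size from one core to the other, and the two steps differ: the same change on two cores in this assay, a 9.3-fold lower number (0.97 log units; beyond the scatter) from compound 1 to compound 3 and a 1.1-fold higher number (0.04 log units; within the scatter) from compound 2 to compound 4, 10-fold (1.00 log units) apart, beyond the scatter of two such steps

The two pairs do not separate the effect of the core from that of the place of the bromo, which differs between them, and two pairs give no rule for any further core.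

Going by these compounds, whether chloro, methyl or a nitrile at the same place would follow compound 3 or compound 4 remains open. Also open, on these data alone, is whether bromo on another carbon of the five-membered aromatic ring of compound 2 would leave the half-life as unmoved as it does in compound 4.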